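A few compounds are considered here, and "the series" means these few. Any claim that something is new, unique, unknown or untested is made for them only; others in the source may bear on it.

Compound 1, `CCC1(Cc2ccccc2)OS(=O)(=O)C=C1OCC(=O)OC`, is the starting point. In an ADME assay on HEL cells (Homo sapiens) for cytotoxicity, with a stated time of 3 days (on this read-out lower numbers stand for higher toxicity in this test and higher numbers for lower toxicity in this test), compound 1 gives > 400000 nM, which is a limit of the test and not a number. Two relatives share its core and differ from it only in the group on a saturated chain carbon bound to an oxygen on an unsaturated carbon. Compound 2, `CCC1(Cc2ccccc2)OS(=O)(=O)C=C1OCc1ccc(F)cc1`, gives >= 50000 nM in this assay, again a limit. Compound 3, `CCC1(Cc2ccccc2)OS(=O)(=O)C=C1OCC1CCCCC1`, gives >= 200000 nM in this assay, also a limit. Accordingly the step that the two limits leave unreadable from compound 1 to compound 2 has no readable size, nor does the step that the two limits leave unreadable from compound 1 to compound 3, and the same holds for a step that the two limits leave unreadable from compound 2 to compound 3. Compound 4, `CCC1(Cc2ccccc2)OS(=O)(=O)C=C1OCc1ccc(Cl)c(Cl)c1`, carries the change (3,4-dichlorophenyl in place of methoxycarbonyl on a saturated chain carbon bound to an oxygen on an unsaturated carbon). Among the compounds with values here, the steps that bear on it cannot be read because each end sits at a limit such as the limit of > 400000 nM in this assay, at which 1 of the 3 values shown sits, the limit of >= 200000 nM in this assay, at which 1 of the 3 values shown sits, or (the limit of >= 50000 nM in this assay, at which 1 of the 3 values shown sits). No direction and no size beyond the scatter can be taken from the measured steps. Compound 4 is expected to show a step of an at least 4.0-fold lower number from compound 1 to compound 4 (0.60 log units; beyond the scatter), and its estimated value in this assay is 100000 nM, between 20000 nM and 400000 nM, most likely reported once more as a limit.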

Compound 4, minimum cytotoxic concentration: >= 20000 nM
Compound 4: only a limit was reported; the forecaster's own chance of this, stated with the estimate: 70%; the middle value is on the limit's open side.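

Within the data shown here, all four values in this assay are limits and not numbers, so no step from compound 1, compound 2 or compound 3 to compound 4 can be read. The compounds shown leave open whether 3,4-dichlorophenyl changes the minimum cytotoxic concentration at all, and by how much.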